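This account rests on a few compounds, and the source may have more. Where it says the series, first, only, none or still open, it means among the compounds named here.

Series notes. Compound 1 `O=C1CN(C2CCCC2)c2nc(Nc3ccc(N4CCCCC4)cn3)ncc2N1` is the parent of this set. In a functional assay on HeLa cells (Homo sapiens) for inhibition, read by MTT assay, with a stated time of 48 h (a lower number here means a stronger inhibitor, a higher number a weaker inhibitor), compound 1 gives only a limit, > 30000 nM. Compound 2 `CC1CCN(c2ccc(Nc3ncc4c(n3)N(C3CCCC3)CC(=O)N4)nc2)CC1` carries methyl in place of hydrogen on a saturated ring carbon. In this assay compound 2 likewise gives only a limit, > 30000 nM. The step that the two limits leave unreadable from compound 1 to compound 2 therefore cannot be sized. Compound 3 `CCN1C(=O)CN(C2CCCC2)c2nc(Nc3ccc(N4CCCCC4)cc3)ncc21` rests on a different core; the difference between the two cores is not broken down here. In this assay compound 3 also returns only a limit, > 30000 nM. Compound 4 `CCN1C(=O)CN(C2CCCC2)c2nc(Nc3ccc(N4CCC(C)CC4)cc3)ncc21` carries methyl in place of hydrogen on a saturated ring carbon, the same change that separates compound 2 from compound 1, at a place described in identical words. All three measured values sit at the limit of > 30000 nM in this assay, at which 3 of the 3 values shown sit. Resting on that limit shared by compound 1, compound 2 and compound 3, the step that the limit leaves unreadable from compound 3 to compound 4 is expected to read like a step that the two limits leave unreadable from compound 1 to compound 2. Compound 4 is expected to give 60000 nM, most likely again only a limit.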

Compound 4, half-maximal inhibitory concentration: > 30000 nM
Compound 4: a limit, no number; the forecaster's own chance of this, stated with the estimate: 85%; the middle value does not contradict the limit.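

Compound 3 and compound 4 both give only a limit, so no step can be read between them: the limit of > 30000 nM in this assay, at which 4 of the 4 values shown sit.

The compounds shown leave open how strongly any of them inhibits in this assay, and what size the change from piperidin-1-yl to 4-methylpiperidin-1-yl has there.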